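A Bicyclic Alcohol in Place of the Methyl Amide

The compounds below may be only part of what the source reports. "The series", "measured", "known", "first", "only" and "open" are said of these compounds alone.

Measured so far:
compound 1 `CNC(=O)c1cc(C(=O)NCCC[C@H]2OC[C@H](N)CO2)cc2c1OC[C@H]2c1ccccc1`: >= 153 ug/mL
compound 2 `CNC(=O)c1cc(C(=O)NC)c2c(c1)[C@H](c1ccccc1)CO2`: >= 130 ug/mL

In a physicochemical assay for solubility (a higher number here means a more soluble compound, a lower number a less soluble compound), compound 1 gives >= 153 ug/mL, which is a limit of the assay. Compound 2 gives >= 130 ug/mL, also a limit. The step that the two limits leave unreadable from compound 1 to compound 2 is therefore unreadable, and compound 2 stands at the limit of >= 130 ug/mL in this assay, at which 1 of the 2 values shown sits. Compound 3 `CNC(=O)c1cc(C(=O)N[C@H]2[C@@H]3C[C@@H](O)C[C@@H]32)cc2c1OC[C@H]2c1ccccc1` differs from compound 2 by a group of 7 heavy atoms (6 carbon, 1 oxygen; one three-membered non-aromatic ring of carbon only, one five-membered non-aromatic ring of carbon only) in place of one carbon atom, on an amide-type nitrogen. Going by the values given here, no measured step reads on this change, so no direction can be inferred from the data. Compound 3 is expected to stay well soluble, with a step of an at least 1.0-fold lower number from compound 2 to compound 3 (0.03 log units; that floor lies within the scatter) from compound 2 to compound 3 that is estimated as small. The estimate for compound 3 is 120 ug/mL, ranging from 40 ug/mL to 250 ug/mL.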

Compound 3, solubility: >= 124 ug/mL
Compound 3 ended at the assay's limit; the forecaster's own chance of this, stated with the estimate: 40%; middle value at least 1.0-fold (0.01 log units) from the limit.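

Going by these compounds alone, no step among compound 1, compound 2 and compound 3 can be read in this assay: each value is a limit of the assay, not a number. These compounds leave open how soluble each one actually is and whether changing the group on the amide-type nitrogen alters that.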